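A few compounds are considered here, and "the series" means these few. Any claim that something is new, unique, unknown or untested is made for them only; others in the source may bear on it.

Compound 1 `O=C(/C=C/CNCCOc1ccc(Oc2c(-c3ccc(F)cc3)sc3cc(O)ccc23)cc1)N1CCCCC1` is one of the two members of this series with a result in a functional assay on MDA-MB-231 cells (Homo sapiens) for antiproliferative activity, read by CCK-8 assay, with a stated time of 48 h; a higher number here means a weaker inhibitor, a lower number a stronger inhibitor. In this assay compound 1 gives only a limit, > 50000 nM. Compound 2 `C=CC(=O)N1CC(Oc2ccc(Oc3c(-c4ccc(F)cc4)sc4cc(O)ccc34)cc2)C1` is the second member. In this assay compound 2 likewise gives only a limit, > 50000 nM. Both results sit at the same edge of the assay (the limit of > 50000 nM in this assay, at which 2 of the 2 values shown sit). Compound 3 `C/C=C/C(=O)N1CC(Oc2ccc(Oc3c(-c4ccc(F)cc4)sc4cc(O)ccc34)cc2)C1` carries the change (prop-1-en-1-yl in place of vinyl on a carbonyl carbon). Among the measured compounds shown here, no step between measured compounds is known, so the step is judged from the change alone; no step beyond the scatter, in either direction, is expected. Compound 3 is estimated near 50000 nM, within 20000 nM to 100000 nM. The step of a number no higher from compound 2 to compound 3 (the limit leaves the size open) is expected to be none beyond the scatter.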

Compound 3, half-maximal inhibitory concentration: > 50000 nM
Compound 3: no number, only a limit; the forecaster's own chance of this, stated with the estimate: 85%; the middle value sits exactly at the limit.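

Compound 2 and compound 3 both give only limits in this assay, so no step can be read between them: the limit of > 50000 nM in this assay, at which 3 of the 3 values shown sit.

The compounds shown leave open whether prop-1-en-1-yl in place of vinyl changes antiproliferative activity on any member that gives a readable number.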